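This account rests on a few compounds, and the source may have more. Where it says the series, first, only, none or still open, it means among the compounds named here.

Measured in an in vitro ADME assay on microsomes (Homo sapiens) for metabolic stability; on this read-out lower numbers stand for a shorter-lived compound and higher numbers for a longer-lived compound:

Compound 1 `CCc1nc(NC(CC)CC)c(OC)nc1-c1ccc(OC(F)F)cc1Cl`: 2 h
Compound 2 `CCc1nc(NC(CC)CC)c(OC)nc1-c1ccc(Cl)cc1Cl`: 0.583 h
Compound 3 `CCC(CC)Nc1nc(OC)c(-c2ccc(Cl)cc2Cl)nc1OC`: 0.267 h

Among these three numbers compound 2 holds the second highest. Its nearest neighbour is compound 3, separated from it by a 2.2-fold lower number from compound 2 to compound 3 (0.34 log units; beyond the scatter); the furthest is compound 1, with a 3.4-fold lower number from compound 1 to compound 2 (0.54 log units; beyond the scatter) between them.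

Compound 4 `CCc1nc(-c2ccc(Cl)cc2Cl)c(CC)nc1NC(CC)CC` has not yet been measured. It differs from compound 2 in one place: ethyl in place of methoxy on an aromatic carbon. Of the two measured steps, only one concerns the same kind of exchange. The step from compound 2 to compound 3 put a methoxy where an ethyl had been, on another aromatic carbon of the shared core, and gave a 2.2-fold lower number from compound 2 to compound 3 (0.34 log units; beyond the scatter). The change to compound 4 runs the opposite way, a methoxy leaving and an ethyl entering, so the same relationship read backwards points to a modestly higher number. The step from compound 1 to compound 2 alters the 2,4-dichlorophenyl group and does not bear on this exchange. Since the carbon involved is not the same one as in the measured step, the expectation is held loosely. Compound 4 is therefore expected to show a 1.7-fold higher number from compound 2 to compound 4 (0.23 log units; within the scatter) in this assay. For compound 4 the estimate in this assay is 1 h, with a range from 0.35 h to 2.5 h.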

Compound 4, half-life: 0.283 h
Beside the measured number, compound 4's estimate is 3.5-fold (0.55 log units) above it, outside the stated range (below it).
By their numbers in this assay, from the lowest: compounds 3 and 4 (each within the scatter of the next); then compound 2; then compound 1.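

In this assay, ethyl in place of methoxy on the carbon next to the ring nitrogen and ortho to the (pentan-3-yl)amino group gives a 2.1-fold lower number from compound 2 to compound 4 (0.31 log units; beyond the scatter), so this position does not simply mirror the earlier exchange. The opposite swap, methoxy in place of the ethyl group that compound 2 carries on another carbon of the shared core, also lowered the half-life, giving a 2.2-fold lower number from compound 2 to compound 3 (0.34 log units; beyond the scatter), which means that the direction of this exchange at one carbon cannot be carried over to the other, and that compound 2, with one methoxy and one ethyl, stands above both of these one-change neighbours. Nothing available explains why either exchange shortens the half-life.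

The compounds shown leave open how a methyl, a cyclopropyl or a longer chain such as propyl on this carbon would compare with methoxy and ethyl. They also leave open whether the difluoromethoxy group, linked to the longer half-life in a 3.4-fold lower number from compound 1 to compound 2 (0.54 log units; beyond the scatter), would make a similar difference on the core of compound 4.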